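Pyridine-linked hydroxyphenyl series: cytotoxicity notes

The source may report more compounds than this note shows. Statements on the series, on what has been measured and on what is new or still open speak of the compounds shown alone.

Measured so far:
compound 1 `Oc1cccc(-c2cc(-c3ccc(Cl)cc3)nc(-c3cccs3)c2)c1` — in a functional assay on T47D cells (Homo sapiens) for cytotoxicity, read by CCK-8 assay and cell counting, with a stated time of 2 days (a lower number here means a stronger inhibitor, a higher number a weaker inhibitor), compound 1 gives 10500 nM
compound 2 `Oc1ccc(-c2cc(-c3ccc(Cl)cc3)nc(-c3cccs3)c2)cc1` — compound 2 gives 6450 nM
compound 3 `Oc1ccc(-c2cc(-c3ccc(Cl)cc3)nc(-c3ccsc3)c2)cc1` — compound 3 gives 5490 nM

Compound 4 `Oc1cccc(-c2cc(-c3ccc(Cl)cc3)nc(-c3ccsc3)c2)c1` is not yet measured. Compound 2 and compound 3 share everything except the group next to the ring nitrogen, the difference being (thiophen-3-yl in place of thiophen-2-yl on an aromatic carbon); the step of a 1.2-fold lower number from compound 2 to compound 3 (0.07 log units; within the scatter) is within the scatter.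

Compound 1 relates to compound 2 through (3-hydroxyphenyl in place of 4-hydroxyphenyl on an aromatic carbon), with a step of a 1.6-fold higher number from compound 2 to compound 1 (0.21 log units; within the scatter), within the scatter. Compound 4 relates to compound 3 through (3-hydroxyphenyl in place of 4-hydroxyphenyl on an aromatic carbon). The surroundings differ only in that the place is meta to a thiophen-3-yl group rather than meta to a thiophen-2-yl group, so this is the same kind of change, not the same one.

Beside a 1.6-fold higher number from compound 2 to compound 1 (0.21 log units; within the scatter), a step of a 1.6-fold higher number from compound 3 to compound 4 (0.20 log units; within the scatter) is expected for compound 4, because compound 3 gives 5490 nM and the single precedent is small. Compound 4 is estimated at 8800 nM, between 4400 nM and 18000 nM.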

Compound 4, half-maximal inhibitory concentration: 11500 nM
Beside the measured number, compound 4's estimate is 1.3-fold (0.12 log units) below it; the range from low to high includes it.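

In this assay, 3-hydroxyphenyl in place of 4-hydroxyphenyl gives a 2.1-fold higher number from compound 3 to compound 4 (0.32 log units; beyond the scatter), and this change carries from the thiophen-2-yl core to the thiophen-3-yl core with no difference beyond the scatter: the same change on two cores in this assay, a 1.6-fold higher number (0.21 log units; within the scatter) from compound 2 to compound 1 and a 2.1-fold higher number (0.32 log units; beyond the scatter) from compound 3 to compound 4, 1.3-fold (0.11 log units) apart, within the scatter of two such steps. Thiophen-3-yl in place of thiophen-2-yl gives a 1.1-fold higher number from compound 1 to compound 4 (0.04 log units; within the scatter), and this change likewise holds on both hydroxyphenyl cores: the same change on two cores in this assay, a 1.2-fold lower number (0.07 log units; within the scatter) from compound 2 to compound 3 and a 1.1-fold higher number (0.04 log units; within the scatter) from compound 1 to compound 4, 1.3-fold (0.11 log units) apart, within the scatter of two such steps. Within the data shown here, this shows agreement within a single set of four compounds in one cell assay, where only one step lies beyond the scatter; it does not show that either change would carry to other cores.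

The compounds shown leave open how an amine or a methoxy group in place of the hydroxyl would read. Also open, as far as these compounds go, is whether an unsubstituted phenyl could replace the 4-chlorophenyl group.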